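A few compounds are considered here, and "the series" means these few. Any claim that something is new, unique, unknown or untested is made for them only; others in the source may bear on it.

Measured compounds:
- compound 1, `COc1ccc(N/C(CCNC2=CC(=O)c3ccccc3C2=O)=N\S(=O)(=O)c2ccc(C)cc2)cc1` — in a functional assay on DU-145 cells (Homo sapiens) for cytotoxicity, read by MTT assay, with a stated time of 48 h (on this read-out lower numbers stand for stronger inhibition and higher numbers for weaker inhibition), compound 1 gives 12000 nM
- compound 2, `Cc1ccc(S(=O)(=O)/N=C(/CCNC2=CC(=O)c3ccccc3C2=O)Nc2cccc(C)c2)cc1` — in this assay compound 2 gives 10200 nM
- compound 3, `Cc1ccc(S(=O)(=O)/N=C(/CCNC2=CC(=O)c3ccccc3C2=O)Nc2cccc(C(F)(F)F)c2)cc1` — in this assay compound 3 gives 84100 nM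

Compound 3 has the highest number of the three: a 7.0-fold higher number from compound 1 to compound 3 (0.85 log units; beyond the scatter) and an 8.2-fold higher number from compound 2 to compound 3 (0.92 log units; beyond the scatter), while a 1.2-fold lower number from compound 1 to compound 2 (0.07 log units; within the scatter) separates the other two only within the scatter. Compound 4, `COc1cc(N/C(CCNC2=CC(=O)c3ccccc3C2=O)=N\S(=O)(=O)c2ccc(C)cc2)cc(OC)c1OC`, has not been measured; it differs from compound 3 by 3,4,5-trimethoxyphenyl in place of 3-(trifluoromethyl)phenyl on an amine nitrogen. The step that bears on this most closely is a 7.0-fold higher number from compound 1 to compound 3 (0.85 log units; beyond the scatter): compound 1, like compound 4, carries a methoxy-bearing phenyl, and reversing that change brings the number back down. A clear drop in the number is therefore expected in this assay, estimated as a 5.6-fold lower number from compound 3 to compound 4 (0.75 log units; beyond the scatter). Compound 4 is expected to give about 15000 nM, between 5000 nM and 50000 nM.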

Compound 4, half-maximal inhibitory concentration: 9330 nM
The estimate for compound 4 lay 1.6-fold (0.21 log units) above the measured number, and the stated range covers the measured number.
By their numbers in this assay, from the lowest: compounds 4, 2 and 1 (each within the scatter of the next); then compound 3.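

In this assay, replacing 3-(trifluoromethyl)phenyl on the amine nitrogen with 3,4,5-trimethoxyphenyl gives a 9.0-fold lower number from compound 3 to compound 4 (0.95 log units; beyond the scatter), so compound 3 stands apart from all three other compounds. The new group performs like the two earlier ones, with a 1.1-fold lower number from compound 2 to compound 4 (0.04 log units; within the scatter) and a 1.3-fold lower number from compound 1 to compound 4 (0.11 log units; within the scatter), so adding methoxy groups to the phenyl brings no gain that can be read here. Nothing measured here explains why the trifluoromethyl compound differs. Going by these compounds, it remains open whether a phenyl bearing a carboxylic acid, or a plain alkyl chain in place of the phenyl, would lower the number further.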